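The source may hold more compounds than are shown below. What is called first, only, known or untested is meant among the compounds shown, and "the series" means these compounds.

In a functional assay on LoVo cells (Homo sapiens) for inhibition, read by MTT assay, with a stated time of 72 h (a lower number here means a stronger inhibitor, a higher number a weaker inhibitor), compound 1 `C=C(Br)C(=O)Nc1cccc(/C=C/C(=O)Nc2cccc(F)c2)c1` gives 1000 nM, compound 2 `C=C(Br)C(=O)Nc1cccc(/C=C/C(=O)Nc2ccc(F)c(F)c2)c1` gives 540 nM and compound 3 `C=C(Br)C(=O)Nc1cccc(/C=C/C(=O)Nc2ccc(C)cc2)c1` gives 1500 nM. Compound 3 lies within the scatter of compound 1, with a 1.5-fold higher number from compound 1 to compound 3 (0.18 log units; within the scatter), and is a weaker inhibitor than compound 2, with a 2.8-fold higher number from compound 2 to compound 3 (0.44 log units; beyond the scatter). Compound 4 `C=C(Br)C(=O)Nc1cccc(/C=C/C(=O)Nc2ccc(OC)cc2)c1` has methoxy in place of methyl on an aromatic carbon, para to a large group (methoxy in place of methyl on an aromatic carbon). For the measured compounds named here, no measured step makes this exact change. The nearest evidence is those two steps and a 1.9-fold lower number from compound 1 to compound 2 (0.27 log units; within the scatter), none larger than modest. The expected step is a 1.2-fold lower number from compound 3 to compound 4 (0.06 log units; within the scatter), within the scatter and without a firm direction. Compound 4 is estimated at 1300 nM, with an expected range from 600 nM to 2800 nM.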

Compound 4, half-maximal inhibitory concentration: 550 nM
Compound 4: the middle estimate sits 2.4-fold (0.37 log units) above what was measured; measured number below the stated range.
By their numbers in this assay, from the lowest: compounds 2, 4, 1 and 3 (each within the scatter of the next, the first and the last beyond it).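

In this assay the swap of methyl for methoxy on this aromatic carbon, para to a large group, gives a step beyond the scatter (a 2.7-fold lower number from compound 3 to compound 4 (0.44 log units; beyond the scatter)), so a single group at this position moves the number measurably. The 4-methoxyphenyl compound lies within the scatter of the 3,4-difluorophenyl compound (a 1.0-fold higher number from compound 2 to compound 4 (0.01 log units; within the scatter)) and of the 3-fluorophenyl compound (a 1.8-fold lower number from compound 1 to compound 4 (0.26 log units; within the scatter)). Nothing measured here explains the methoxy step.

As far as these compounds go, what remains open is how an amine, a hydroxyl or a longer chain such as ethoxy would read at this position.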